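Aryl change on the ring nitrogen: outlook for compound 4

A few compounds are considered here, and "the series" means these few. Any claim that something is new, unique, unknown or untested is made for them only; others in the source may bear on it.

Measured so far:
compound 1, `CNC(=O)c1cc(Oc2ccc(NC(=O)c3cc4cccnc4n(-c4ccccc4F)c3=O)cc2)ccn1`, in a functional assay on A549 cells (Homo sapiens) for antiproliferative activity, read by MTT assay, with a stated time of 72 h (a higher number here means a weaker inhibitor, a lower number a stronger inhibitor), 610 nM
compound 2, `CNC(=O)c1cc(Oc2ccc(NC(=O)c3cc4cccnc4n(-c4ccc(F)cc4)c3=O)cc2)ccn1`, in this assay 110 nM
compound 3, `CCNC(=O)c1cc(Oc2ccc(NC(=O)c3cc4cccnc4n(-c4ccc(F)cc4)c3=O)cc2)ccn1`, in this assay 120 nM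

Compound 3 holds the second highest of the three numbers; it sits within the scatter of compound 2, and its value is clearly apart from that of compound 1. Compound 4, `CCNC(=O)c1cc(Oc2ccc(NC(=O)c3cc4cccnc4n(-c4ccc(C(F)(F)F)cc4Cl)c3=O)cc2)ccn1`, differs from compound 3 by 2-chloro-4-(trifluoromethyl)phenyl in place of 4-fluorophenyl on an aromatic nitrogen. For the measured compounds named here, the only measured step at this place is a 5.5-fold lower number from compound 1 to compound 2 (0.74 log units; beyond the scatter); the step of a 1.1-fold higher number from compound 2 to compound 3 (0.04 log units; within the scatter) concerns another position and was flat. A change of this kind at the aromatic nitrogen has thus once moved the number modestly, and for compound 4 a step of comparable size toward a higher number is expected, a 2.5-fold higher number from compound 3 to compound 4 (0.40 log units; beyond the scatter). Compound 4 is therefore estimated at 300 nM, within 100 nM to 1000 nM.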

Compound 4, half-maximal inhibitory concentration: 3290 nM
The estimate for compound 4 lay 11-fold (1.04 log units) below the measured number; measured number outside the range, above it.
By their numbers in this assay, from the lowest: compounds 2 and 3 (each within the scatter of the next); then compound 1; then compound 4.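

In this assay, for the compounds shown here, this position proves far more sensitive than the earlier compounds showed: 2-chloro-4-(trifluoromethyl)phenyl in place of 4-fluorophenyl gives a 27-fold higher number from compound 3 to compound 4 (1.44 log units; beyond the scatter), a large step, compared with the modest 5.5-fold lower number from compound 1 to compound 2 (0.74 log units; beyond the scatter). No pairing so far shows a change on this aromatic nitrogen that leaves the number within the scatter. No supporting data bear on the size of this step.

As far as these compounds go, the chlorine and the trifluoromethyl enter together, so their separate contributions remain open. Also open, from the compounds shown here alone, is how a phenyl carrying an amine or a carboxylic acid would read at this nitrogen.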